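A few compounds are considered here, and "the series" means these few. Any claim that something is new, unique, unknown or untested is made for them only; others in the source may bear on it.

Compound 1 (`O=C(Nc1cccc(Cl)c1)Nc1cc2ncncc2cc1OCc1cccc(Cl)c1`) and compound 2 (`O=C(Nc1ccc(C(F)(F)F)cc1)Nc1cc2ncncc2cc1OCc1cccc(Cl)c1`) differ only in the group on an amide-type nitrogen. Going by the values given here, in a functional assay on GBM1 cells (Homo sapiens) for antiproliferative activity, read by WST assay, with a stated time of 72 h (a higher number here means a weaker inhibitor, a lower number a stronger inhibitor), compound 1 gives 3300 nM and compound 2 gives 3400 nM as its value, so compound 2 stands within the scatter of the only other number available.

Compound 3 (`O=C(Nc1cccc(F)c1)Nc1cc2ncncc2cc1OCc1cccc(Cl)c1`) departs from compound 2 at that same place, on the amide-type nitrogen whose other neighbour is the carbonyl carbon, with 3-fluorophenyl in place of 4-(trifluoromethyl)phenyl (3-fluorophenyl in place of 4-(trifluoromethyl)phenyl on an amide-type nitrogen). Among the compounds with values here, only one measured step bears on this, the exchange of 3-chlorophenyl for 4-(trifluoromethyl)phenyl at the same place, which came to a 1.0-fold higher number from compound 1 to compound 2 (0.01 log units; within the scatter) and so stayed within the scatter. Within the data shown here, no measured compound yet carries 3-fluorophenyl, so this single step is thin support. Resting on compound 2 at 3400 nM and on that one step, no change beyond the scatter is expected in this assay in either direction. The estimate therefore means a 1.0-fold lower number from compound 2 to compound 3 (0.01 log units; within the scatter) as the expected step. For compound 3 the estimated value is 3300 nM with an expected range from 1500 nM to 7000 nM in all.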

Compound 3, half-maximal inhibitory concentration: 3700 nM
Compound 3: middle estimate off by 1.1-fold (0.05 log units), on the low side; low and high end bracket the measured number.
By their numbers in this assay, from the lowest: compounds 1, 2 and 3 (each within the scatter of the next).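

With 3-fluorophenyl in place of 4-(trifluoromethyl)phenyl on the amide-type nitrogen, this assay shows a 1.1-fold higher number from compound 2 to compound 3 (0.04 log units; within the scatter) even though the entering group has fewer heavy atoms, so this third group also cannot be told apart from the others at this position. The narrower change of fluoro in place of chloro on an aromatic carbon gives a 1.1-fold higher number from compound 1 to compound 3 (0.05 log units; within the scatter) and adds a second direct comparison, showing that this exchange of one atom on the ring also stays within the scatter. Compound 1, compound 2 and compound 3 therefore form a level set in this assay, and no measured evidence is at hand to account for that. On these data alone, all three compounds carry a phenyl group bearing chlorine or fluorine on this nitrogen, so it remains open whether the same level holds for a phenyl bearing an amine or a carboxylic acid, for an unsubstituted phenyl, or for a cyclohexyl or a longer alkyl chain in its place. The compounds also leave open how much the 3-chlorobenzyl ether, held constant throughout, contributes to the values seen.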